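The source may report more compounds than this note shows. Statements on the series, on what has been measured and on what is new or still open speak of the compounds shown alone.

Compound 1, `C[C@]1(O)CC(=O)O[C@H](CCc2ccc(Cl)cc2Cl)C1`, gives 37% in an assay for inhibition of 3-hydroxy-3-methylglutaryl-coenzyme A reductase (Rattus norvegicus), tested at 4 ug/mL; a lower number here means a weaker effect, a higher number a stronger effect of the compound at the concentration tested. Compound 2, `CO[C@H]1C[C@H](O)C[C@@H](/C=C/c2ccc(Cl)cc2Cl)O1`, gives 2% in this assay, the lowest of the two numbers and beyond the scatter from compound 1. Compound 3, `CO[C@@H]1C[C@H](O)C[C@@H](/C=C/c2ccc(Cl)cc2Cl)O1`, has not yet been tested. Its difference from compound 2 is the two compounds have the same atoms and bonds and differ only in configuration as drawn: 1 of 4 stereo elements differ; a stereocentre at a saturated ring carbon is drawn R in compound 2 and S in compound 3. For the measured compounds named here, no step between measured compounds shows what such an inversion does here, so only a small shift is expected in this assay, with no clear direction beyond the scatter. For compound 3 the expected read-out is 8%, within 0% to 30%, a step of a number 6 percentage points higher from compound 2 to compound 3 (within the scatter).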

Compound 3, a percentage reported as inhibition, at one concentration (the size of the read-out at that concentration, not a potency): 0%
Compound 3: the middle estimate sits 8 percentage points above what was measured; the measured number falls inside the stated range.
By their numbers in this assay, from the lowest: compounds 3 and 2 (each within the scatter of the next); then compound 1.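

Inverting the stereocentre at this saturated ring carbon gives a step of a number 2 percentage points lower from compound 2 to compound 3 (within the scatter) in this assay, so neither drawn configuration stands out here. This is the first step shown that can be read as a single change, and that reading rests on one thing: the fact that compounds 2 and 3 differ only in the configuration as drawn. Both read-outs lie close to zero, however, so the step says little about how the inversion would act in a more active compound. Open, from the compounds shown here alone, is whether an amine or a carboxylic acid on this carbon would raise the read-out, and whether configuration would then matter.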